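Amine swap on a thioalkyl chain: T-type channel series

This account rests on a few compounds, and the source may have more. Where it says the series, first, only, none or still open, it means among the compounds named here.

Measured in an assay on cells for inhibition of Voltage-dependent T-type calcium channel subunit alpha-1I (Homo sapiens), read by patch clamp; on this read-out lower numbers stand for stronger inhibition and higher numbers for weaker inhibition:

compound 1, `O=C(CC1c2ccccc2N=C(SCCCCCN2CCCC2)N1c1ccc(-c2ccccc2)cc1)NCc1ccc(F)cc1`: 13600 nM
compound 2, `CN(C)CCCCCSC1=Nc2ccccc2C(CC(=O)NCc2ccc(F)cc2)N1c1ccc(-c2ccccc2)cc1`: 6100 nM
compound 3, `CN(C)CCCCCSC1=Nc2ccccc2C(CC(=O)NCc2ccccc2)N1c1ccccc1`: 3200 nM

Compound 2 and compound 3 differ in more than one place; the difference between their two cores is not broken down here. Their two numbers in this assay lie within the usual scatter of each other, so no order between them is claimed. The gap between compound 3 and compound 1 lies beyond the scatter.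

One change is seen twice in the set. From compound 2 to compound 1 it is pyrrolidin-1-yl in place of dimethylamino on a saturated chain carbon, five bonds along the chain from a sulfur and it gave a 2.2-fold higher number from compound 2 to compound 1 (0.35 log units; beyond the scatter): a modest move towards weaker inhibition. The same change, word for word at the same place, carries compound 3 to compound 4, `O=C(CC1c2ccccc2N=C(SCCCCCN2CCCC2)N1c1ccccc1)NCc1ccccc1`, as pyrrolidin-1-yl in place of dimethylamino on a saturated chain carbon, five bonds along the chain from a sulfur. Compound 4 has not yet been measured in this assay.

Within the data shown here, with only one earlier instance to rest on, the expectation for compound 4 is a step of about the same size and direction, a 2.1-fold higher number from compound 3 to compound 4 (0.33 log units; beyond the scatter), because the single precedent a 2.2-fold higher number from compound 2 to compound 1 (0.35 log units; beyond the scatter) pointed to weaker inhibition. The core of compound 3 is not the core of compound 2, so the transfer is uncertain and the range is kept wide. Compound 4 is thus estimated at 6800 nM in this assay, with a plausible span from 2600 nM to 18000 nM.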

Compound 4, half-maximal inhibitory concentration: 6190 nM
For compound 4 the middle estimate is 1.1-fold (0.04 log units) above the measured one; the measured number falls inside the stated range.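

In this assay, the exchange of dimethylamino for pyrrolidin-1-yl, on a saturated chain carbon, five bonds along the chain from a sulfur, now reads on a second core as a 1.9-fold higher number from compound 3 to compound 4 (0.29 log units; within the scatter), and the two readings agree: the same change on two cores in this assay, a 2.2-fold higher number (0.35 log units; beyond the scatter) from compound 2 to compound 1 and a 1.9-fold higher number (0.29 log units; within the scatter) from compound 3 to compound 4, 1.2-fold (0.06 log units) apart, within the scatter of two such steps.
On these two cores, then, the change carries over with no detectable dependence on the core, and the step keeps the same sign on both. It does not show a firm loss on the core of compound 3, where the step alone stays within the scatter, and two matched pairs give no rule for the whole series, nor any reason for the size of the step.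

As far as these compounds go, the amine has been read only as dimethylamino and pyrrolidin-1-yl, so whether the same step would hold for a piperidine, a morpholine or a diethylamino group remains open, as does its behaviour on a shorter or longer chain to the sulfur. The differences between the cores of compound 2 and compound 3 also remain unseparated, so what each one contributes on its own cannot be read from these compounds.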